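The compounds below may be only part of what the source reports. "The series", "measured", "known", "first", "only" and "open" are said of these compounds alone.

Going by the values given here, compound 2 `COc1ccc2c(=O)c(/C=C/C(=O)NCc3ccc(F)cc3)coc2c1` gives 133000 nM in an ADME assay on HepG2 2.2.15 cells (Homo sapiens) for cytotoxicity, read by MTT assay, with stated times of 48 h and 9 days (a lower number here means that less compound is tolerated, a higher number that more compound is tolerated), the lowest of the two numbers measured so far; compound 1 `COc1ccc2c(=O)c(/C=C/C(=O)Nc3ccccc3Cl)coc2c1` gives 1010000 nM. Among the compounds with values here, only one measured step bears on the change to compound 3 `COc1ccc2c(=O)c(/C=C/C(=O)Nc3ccc(F)cc3)coc2c1`, namely a 7.6-fold lower number from compound 1 to compound 2 (0.88 log units; beyond the scatter), where an aryl group on the amide nitrogen was replaced by a benzyl group. The change now made is 4-fluorophenyl in place of 4-fluorobenzyl on an amide-type nitrogen, which returns an aryl group to that nitrogen. Compound 3 is therefore expected to show a step of a 3.8-fold higher number from compound 2 to compound 3 (0.58 log units; beyond the scatter), estimated from that single comparison. Compound 3 is expected at 500000 nM, between 150000 nM and 1500000 nM.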

Compound 3, half-maximal cytotoxic concentration: 743000 nM
For compound 3 the middle estimate is 1.5-fold (0.17 log units) below the measured one; the range from low to high includes it.
By their numbers in this assay, from the lowest: compound 2; then compounds 3 and 1 (each within the scatter of the next).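

The a 5.6-fold higher number from compound 2 to compound 3 (0.75 log units; beyond the scatter) shows the benzyl-to-aryl change on the amide-type nitrogen working with the 4-fluoro ring kept, so the earlier drop from compound 1 to compound 2 was not tied to the 2-chlorophenyl group alone. The a 1.4-fold lower number from compound 1 to compound 3 (0.13 log units; within the scatter) places the two aryl groups within the scatter of each other, leaving compound 2 apart from both. No measurement shown gives a reason for this. The compounds leave open how a longer chain such as phenylethyl on that nitrogen would stand, and whether an aryl group carrying an amine or a carboxylic acid would stay with compound 1 and compound 3.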